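From 3-(trifluoromethyl)phenyl to 3,4-dichlorophenyl on the amide nitrogen

A few compounds are considered here, and "the series" means these few. Any claim that something is new, unique, unknown or untested is made for them only; others in the source may bear on it.

In a functional assay on A-431 cells (Homo sapiens) for antiproliferative activity, read by MTT assay, with a stated time of 48 h (a higher number here means a weaker inhibitor, a lower number a stronger inhibitor), compound 1 `O=C(CCCCCC(=O)Nc1ccc(O)c(C(=O)Nc2ccccc2)c1)NO` gives 5850 nM, and compound 2 `O=C(CCCCCC(=O)Nc1ccc(O)c(C(=O)Nc2cccc(C(F)(F)F)c2)c1)NO` gives 2750 nM, the lower of the two numbers and therefore the stronger result so far. The step between them, a 2.1-fold lower number from compound 1 to compound 2 (0.33 log units; beyond the scatter), accompanies trifluoromethyl in place of hydrogen on an aromatic carbon, and it is modest, though beyond the usual scatter.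

Compound 3 `O=C(CCCCCC(=O)Nc1ccc(O)c(C(=O)Nc2ccc(Cl)c(Cl)c2)c1)NO` differs from compound 2 in one place: 3,4-dichlorophenyl in place of 3-(trifluoromethyl)phenyl on an amide-type nitrogen. In words, this is 3,4-dichlorophenyl in place of 3-(trifluoromethyl)phenyl on an amide-type nitrogen. Within the data shown here, no measured step swaps one substituted phenyl group for another, so the evidence is indirect. Among the measured compounds shown here, the only step available, a 2.1-fold lower number from compound 1 to compound 2 (0.33 log units; beyond the scatter), adds a substituent to a plain phenyl group and is small. On that basis, replacing one substituted phenyl group with another is expected to make little difference in this assay, with no firm direction. The expected step is a 1.1-fold lower number from compound 2 to compound 3 (0.04 log units; within the scatter), which would not stand clear of the scatter. For compound 3 the estimate is 2500 nM, with an expected range from 1100 nM to 5500 nM.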

Compound 3, half-maximal inhibitory concentration: 3800 nM
Compound 3: the middle estimate sits 1.5-fold (0.18 log units) below what was measured; measured number inside the range.
By their numbers in this assay, from the lowest: compounds 2, 3 and 1 (each within the scatter of the next, the first and the last beyond it).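

In this assay, the exchange of one substituted phenyl group for another on the amide-type nitrogen gives a 1.4-fold higher number from compound 2 to compound 3 (0.14 log units; within the scatter), so at this position the data do not separate 3,4-dichlorophenyl from 3-(trifluoromethyl)phenyl. Compared with the plain phenyl group, the new group gives a 1.5-fold lower number from compound 1 to compound 3 (0.19 log units; within the scatter), so a substituted phenyl group here does not always stand clear of the plain one: of the two substituted groups shown, only the 3-(trifluoromethyl)phenyl group of compound 2 does, and only modestly. No other measurement is available that could explain these small differences.

On these data alone, all three numbers lie close together, so it remains open whether a quite different group on this nitrogen, such as a pyridine ring or a phenyl ring carrying an amine or a carboxylic acid, would shift the number by a much larger step. It is also open whether a longer chain in place of the one shared by all three compounds would change the number more than any exchange of the phenyl group shown so far.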